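A few compounds are considered here, and "the series" means these few. Any claim that something is new, unique, unknown or untested is made for them only; others in the source may bear on it.

Three compounds share one core and differ in the aromatic ring fixed to a saturated ring carbon. Compound 1, `COc1c(F)cccc1C1CCN(c2ccn3c(CC(F)(F)F)nnc3c2C#N)CC1`, gives 306% in a functional assay on CHO cells for agonist activity at metabotropic glutamate receptor 2 (Homo sapiens), read by scintillation counting and GTPgammaS binding, with a stated time of 30 min; a higher number here means a larger maximal response, a lower number a smaller maximal response. Compound 2, `COc1ccc(F)cc1C1CCN(c2ccn3c(CC4CC4)nnc3c2Cl)CC1`, gives 283% in this assay, and compound 3, `COc1cccc(F)c1C1CCN(c2ccn3c(CC4CC4)nnc3c2Cl)CC1`, gives 304%. Compound 3 stands second highest of the three: its number lies within the scatter of that of compound 1, while the step of a number 21 percentage points higher from compound 2 to compound 3 (beyond the scatter) lies beyond it.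

Compound 4, `COc1c(C2CCN(c3ccn4c(CC5CC5)nnc4c3Cl)CC2)ccc(F)c1F`, has not yet been measured in this assay. It differs from compound 3 by 3,4-difluoro-2-methoxyphenyl in place of 2-fluoro-6-methoxyphenyl on a saturated ring carbon. Both rings carry a methoxy group, so the change concerns the fluorine substitution of the ring.

Going by the values given here, only one measured step bears on such a change: a number 21 percentage points higher from compound 2 to compound 3 (beyond the scatter), where the fluorine of a methoxy-bearing ring was placed differently. Among the compounds with values here, that step was modest, and no measured step shows what adding a second fluorine does. For compound 4, therefore, a step no larger than the scatter is expected, and the estimate is 295%, with a range from 255% to 335%. The expected step from compound 3 is then a number 9 percentage points lower from compound 3 to compound 4 (within the scatter), which is small.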

Compound 4, largest response reached (Emax), in percent of the reference or control that the assay uses: 342%
Compound 4: the middle estimate sits 47 percentage points below what was measured; measured number above the stated range.
By their numbers in this assay, from the lowest: compound 2; then compounds 3 and 1 (each within the scatter of the next); then compound 4.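

Going by these compounds alone, at this place on the saturated ring, the aromatic ring's substitution can shift the largest response by more than the earlier compounds showed. In this assay, 3,4-difluoro-2-methoxyphenyl in place of 2-fluoro-6-methoxyphenyl gives a number 38 percentage points higher from compound 3 to compound 4 (beyond the scatter), and in place of 5-fluoro-2-methoxyphenyl it gives a number 59 percentage points higher from compound 2 to compound 4 (beyond the scatter). Both steps exceed the modest change seen between the two monofluorinated rings, so a ring with a second fluorine does not lose the response here and, among these three otherwise matched compounds, reaches the highest number; nothing available explains why this ring does so.

Within the data shown here, the two fluorines of compound 4 also sit differently from the single fluorine of compound 3 and compound 2, so these compounds cannot separate the effect of adding a fluorine from the effect of where the fluorines stand. From the compounds shown here alone, it also remains open how the response would change with an amine or an ethoxy group in place of the methoxy group on this ring, or with a chlorine in place of either fluorine.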